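Two Chlorophenyl Ethers Compared in One Serotonin Receptor Assay

This account rests on a few compounds, and the source may have more. Where it says the series, first, only, none or still open, it means among the compounds named here.

Measured so far:
compound 1 `CN1CCN(c2nc(N)nc(COc3ccccc3Cl)n2)CC1`: 9250 nM
compound 2 `CC(Oc1cccc(Cl)c1)c1nc(N)nc(N2CCN(C)CC2)n1`: 8360 nM

In an assay on HEK293 cells for displacement of a labelled ligand from 5-hydroxytryptamine receptor 7 (Homo sapiens), read by radioligand binding, with a stated time of 1 h (on this read-out higher numbers stand for weaker inhibition and lower numbers for stronger inhibition), compound 1 gives 9250 nM. In this assay compound 2 gives 8360 nM. The two numbers lie within the usual scatter of each other, so compound 2 stands alongside compound 1 without any distinction the assay can resolve; both point to weak displacement of the labelled ligand. Compound 1 and compound 2 differ in two places at once, so their pair does not isolate either change.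

Compound 3 `CC(Oc1ccccc1Cl)c1nc(N)nc(N2CCN(C)CC2)n1` has not been measured yet. It departs from compound 2 by one change: 2-chlorophenyl in place of 3-chlorophenyl on an oxygen on a saturated carbon. Both measured compounds share the same core and both carry a chlorine on the phenyl ring, and their values are within the scatter of each other, so no step beyond the scatter is expected from moving the chlorine alone. Compound 3 is therefore expected to give about 9000 nM, with a range of 3500 nM to 25000 nM. The step expected from compound 2 to compound 3 is a 1.1-fold higher number from compound 2 to compound 3 (0.03 log units; within the scatter), within the scatter.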

Compound 3, inhibition constant: 38700 nM
Estimate against measurement, compound 3: 4.3-fold (0.63 log units) below; measured number outside the range, above it.
By their numbers in this assay, from the lowest: compounds 2 and 1 (each within the scatter of the next); then compound 3.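

In this assay the place of the chlorine on the phenyl ring of this ether proves to matter: with the same atoms joined differently, 2-chlorophenyl in place of 3-chlorophenyl gives a 4.6-fold higher number from compound 2 to compound 3 (0.67 log units; beyond the scatter) and so moves the result beyond the scatter. The saturated chain carbon is a second place that responds, since methyl in place of hydrogen there, with 2-chlorophenoxy kept, gives a 4.2-fold higher number from compound 1 to compound 3 (0.62 log units; beyond the scatter) and again points to weaker displacement of the labelled ligand. No measurement at hand bears on why either step occurs.

The compounds shown carry only chlorine on the phenyl ring and only hydrogen or methyl on the saturated chain carbon, so it remains open how a fluorine or a methoxy group in place of the chlorine, or an ethyl group in place of the methyl, would read. From the compounds shown here alone, it is also open whether moving the chlorine has the same effect when that carbon carries hydrogen rather than methyl, a question that would need the 3-chlorophenyl ether with hydrogen there.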